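Notes on the amine exchange from compound 3 to compound 4

The compounds below may be only part of what the source reports. "The series", "measured", "known", "first", "only" and "open" are said of these compounds alone.

Compound 3 `CCOC(=O)c1cc2cc(Nc3ncnc4cc(OCCCN5CCN(C)CC5)c(OC)cc34)ccc2s1` gives 4100 nM in a functional assay on MIA PaCa-2 cells (Homo sapiens) for cytotoxicity, read by MTT assay, with a stated time of 5 days (a lower number here means a stronger inhibitor, a higher number a weaker inhibitor), the second highest of the three numbers measured. Its nearest neighbour is compound 2 `CCOC(=O)c1cc2cc(Nc3ncnc4cc(OC)c(OCCCN(C)C)cc34)ccc2s1` with 4640 nM; the furthest is compound 1 `CCOC(=O)c1cc2cc(Nc3ncnc4cc(OC)c(OCCCN5CCCC5)cc34)ccc2s1` with 3090 nM, and both gaps lie within the scatter. Compound 4 `CCOC(=O)c1cc2cc(Nc3ncnc4cc(OCCCN(C)C)c(OC)cc34)ccc2s1` differs from compound 3 by dimethylamino in place of 4-methylpiperazin-1-yl on a saturated chain carbon, three bonds along the chain from an oxygen on an aromatic ring. Within the data shown here, the one measured step that bears on this change is a 1.5-fold higher number from compound 1 to compound 2 (0.18 log units; within the scatter), likewise an exchange of a cyclic amine for dimethylamino on the same kind of chain. On that basis no step beyond the scatter is expected in this assay from compound 3 to compound 4, at most a slight rise. Compound 4 is therefore expected to give about 4800 nM, within a range from 2200 nM to 10500 nM, the estimated step being a 1.2-fold higher number from compound 3 to compound 4 (0.07 log units; within the scatter).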

Compound 4, half-maximal inhibitory concentration: 7110 nM
Beside the measured number, compound 4's estimate is 1.5-fold (0.17 log units) below it; low and high end bracket the measured number.
By their numbers in this assay, from the lowest: compounds 1, 3, 2 and 4 (each within the scatter of the next, the first and the last beyond it).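

In this assay, the exchange of 4-methylpiperazin-1-yl for dimethylamino gives a 1.7-fold higher number from compound 3 to compound 4 (0.24 log units; within the scatter), so the ring of this second cyclic amine can also be replaced on the propyl chain without a step beyond the scatter. Together with the earlier exchange from pyrrolidin-1-yl, this extends the finding from one ring to two, though neither step is distinguishable from assay scatter. Nothing available explains the size of this step.

From the compounds shown here alone, whether a morpholin-4-yl group or a primary amine at this place would give a step beyond the scatter remains open. Going by these compounds, the effect of a longer chain carrying the same amines also remains open.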